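The source may hold more compounds than are shown below. What is called first, only, known or untested is meant among the compounds shown, and "the series" means these compounds.

Measured compounds:
- compound 1 `COc1cc(-c2cc(/C=C/C(=O)c3ccc(N)cc3)[nH]n2)cc(OC)c1OC` gives 99%
- compound 2 `COc1ccc(-c2cc(/C=C/C(=O)c3ccc(N)cc3)[nH]n2)cc1OC` gives 102%
- compound 3 `COc1cc(C(=O)/C=C/c2cc(-c3cc(OC)c(OC)c(OC)c3)n[nH]2)cc(OC)c1OC` gives 101%

All three were run in a functional assay on LOX IMVI cells (Homo sapiens) for cytotoxicity, read by sulforhodamine B assay, with a stated time of 48 h, tested at 0.1 uM; on this read-out lower numbers stand for a stronger effect and higher numbers for a weaker effect at the one concentration tested. Compound 1 gives 99% and compound 2 gives 102%, so none of the three shows a marked effect at the concentration tested. Compound 1 and compound 2 differ in one place: hydrogen in place of methoxy on an aromatic carbon. This change made a step of a number 3 percentage points higher from compound 1 to compound 2 (within the scatter), within the scatter, so nothing can be read into its direction.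

Compound 3 gives 101% in this assay. The difference between the core of compound 3 and the core of compound 1 is not broken down here; their two values lie within the scatter of each other, and the same holds for compound 3 against compound 2.

Compound 4 `COc1ccc(-c2cc(/C=C/C(=O)c3cc(OC)c(OC)c(OC)c3)[nH]n2)cc1OC` has not been measured. It differs from compound 3 in one place: hydrogen in place of methoxy on an aromatic carbon. This is the same change as the one between compound 1 and compound 2, at a place described in the same words, and it occurs twice among the compounds shown.

For compound 4 in this assay the expected step is no change at the digits printed from compound 3 to compound 4 (within the scatter), beside the earlier one of a number 3 percentage points higher from compound 1 to compound 2 (within the scatter), because the earlier step lay within the scatter and compound 3 starts from 101%, a value with no room for a weaker effect. Compound 4 is estimated at 101%, with a range from 92% to 110% expected.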

Compound 4, a percentage reported as activity, at one concentration (the size of the read-out at that concentration, not a potency): 94%
Compound 4: the middle estimate sits 7 percentage points above what was measured, within the range that was stated.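

In this assay, hydrogen in place of methoxy on an aromatic carbon now gives a second step, a number 7 percentage points lower from compound 3 to compound 4 (within the scatter), on a core carrying methoxy groups on both aromatic ends. Set beside the earlier step, the change gives no sign of behaving differently on the two cores: the same change on two cores in this assay, a number 3 percentage points higher (within the scatter) from compound 1 to compound 2 and a number 7 percentage points lower (within the scatter) from compound 3 to compound 4, 10 percentage points apart, within the scatter of two such steps This does not show that the change transfers from one core to the other, as neither step is distinguishable from scatter, so the series holds no measurable effect of this change to carry across, and opposite signs of the two steps carry no meaning.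

The compounds shown leave open how this change behaves at a concentration where the series gives a marked effect on these cells, as the single concentration here gives no step that can be read beyond the scatter. Also open, on these data alone, is whether a different group at the same place, such as a hydroxy group, a chlorine atom or a carboxylic acid in place of the methoxy, would move the read-out beyond the scatter on either core.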